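Acetyl in place of furoyl on a shared enone amide core

A few compounds are considered here, and "the series" means these few. Any claim that something is new, unique, unknown or untested is made for them only; others in the source may bear on it.

Measured compounds:
- compound 1, `COc1cc(/C=C/C(=O)c2cccc(NC(=O)c3ccco3)c2)ccc1O`: 6.65 ug/mL
- compound 2, `COc1cc(/C=C/C(=O)c2cccc(N)c2)ccc1O`: 7.71 ug/mL
- compound 3, `COc1cc(/C=C/C(=O)c2cccc(NC(=O)C(C)C)c2)ccc1O`: 8.31 ug/mL

In a functional assay on U-87MG ATCC cells (Homo sapiens) for inhibition (a higher number here means a weaker inhibitor, a lower number a stronger inhibitor), compound 1 gives the lowest of the three numbers shown, though none of the three is separated from another by more than the scatter: the step of a 1.2-fold higher number from compound 1 to compound 2 (0.06 log units; within the scatter) and the step of a 1.2-fold higher number from compound 1 to compound 3 (0.10 log units; within the scatter) both stay inside it, as does the step of a 1.1-fold higher number from compound 2 to compound 3 (0.03 log units; within the scatter). Compound 4, `COc1cc(/C=C/C(=O)c2cccc(NC(C)=O)c2)ccc1O`, has not yet been measured in this assay. It differs from compound 1 in one place: methyl in place of furan-2-yl on a carbonyl carbon.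

Among the compounds with values here, two measured steps bear on this change. The step of a 1.2-fold higher number from compound 1 to compound 3 (0.10 log units; within the scatter) swaps the same furan-2-yl on the carbonyl carbon for another small carbon group and shows no movement beyond the scatter. The step of a 1.2-fold higher number from compound 1 to compound 2 (0.06 log units; within the scatter) removes the (furan-2-yl)carbonyl from the nitrogen altogether, and again nothing beyond the scatter follows. The change to methyl sits between these two in size, so no step beyond the scatter is expected in this assay, in either direction.

Compound 4 is therefore expected to give about 7.5 ug/mL in this assay, between 4.5 ug/mL and 12.5 ug/mL. The expected step of a 1.1-fold higher number from compound 1 to compound 4 (0.05 log units; within the scatter) is thus estimated to lie within the scatter.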

Compound 4, half-maximal inhibitory concentration: > 50 ug/mL
Compound 4 ended at the assay's limit; the forecaster's own chance of this, stated with the estimate: 3%; at least 6.6-fold (0.82 log units) between middle value and limit.
By their numbers in this assay, from the lowest: compounds 1, 2 and 3 (each within the scatter of the next). At a limit, above all of these: compound 4.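

In this assay compound 4 gives > 50 ug/mL, which is a limit of the assay and not a number: the limit of > 50 ug/mL in this assay, at which 1 of the 4 values shown sits.

The acetyl compound separates from all three earlier compounds, with an at least 7.5-fold higher number from compound 1 to compound 4 (0.87 log units; beyond the scatter), an at least 6.0-fold higher number from compound 3 to compound 4 (0.77 log units; beyond the scatter) and an at least 6.4-fold higher number from compound 2 to compound 4 (0.81 log units; beyond the scatter), although those three lie within the scatter of one another. The group on the carbonyl carbon therefore matters at this position after all, and the number does not follow the size of that group: compound 2, with hydrogen on the nitrogen in place of the whole acyl group, stays with compound 1 and compound 3, while compound 4, with the intermediate acetyl, does not.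

The compounds shown leave open whether this drop belongs to methyl alone or extends to other small groups on the carbonyl carbon, such as an ethyl, a cyclopropyl or a methoxy. They also leave open what lies behind the drop and, with compound 4 standing at a limit, how large it really is.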